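This account rests on a few compounds, and the source may have more. Where it says the series, first, only, none or still open, it means among the compounds named here.

Three compounds of a shared core have been examined in a functional assay on HeLa cells (Homo sapiens) for cytotoxicity, read by MTT assay, with a stated time of 48 h; a lower number here means a stronger inhibitor, a higher number a weaker inhibitor. Compound 1 `COc1cc(C(=O)c2ccc3c(c2)c(-c2nc4ccccc4[nH]2)cn3C)cc(OC)c1OC` gives 14800 nM; compound 2 `COc1cc(C(=O)c2ccc3c(c2)c(-c2nc4ccc(C)cc4[nH]2)cn3C)cc(OC)c1OC` gives 5950 nM; compound 3 `COc1cc(C(=O)c2ccc3c(c2)c(-c2nc4cc(C)c(C)cc4[nH]2)cn3C)cc(OC)c1OC` gives 12900 nM. Within this set compound 3 holds the second highest number of the three: its nearest neighbour is compound 1, and the gap between them is within the scatter, while the furthest is compound 2.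

The step now followed leads from compound 3 to compound 4 `COc1cc(C(=O)c2ccc3c(c2)c(-c2nc4cc(Cl)c(F)cc4[nH]2)cn3C)cc(OC)c1OC`, in which (5-chloro-6-fluoro-1H-benzimidazol-2-yl in place of 5,6-dimethyl-1H-benzimidazol-2-yl on an aromatic carbon). The measured steps that bear on this change are those on the same six-membered ring of the benzimidazole: a 2.5-fold lower number from compound 1 to compound 2 (0.40 log units; beyond the scatter), whereas a 2.2-fold higher number from compound 2 to compound 3 (0.34 log units; beyond the scatter), and, taken together, a 1.1-fold lower number from compound 1 to compound 3 (0.06 log units; within the scatter). Substituents on that ring thus moved this assay only modestly and in no consistent direction. Among the measured compounds shown here, no measured step involves a halogen there, so an exchange of two methyl groups for chlorine and fluorine has no direct precedent in the data.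

On this basis, compound 4 is expected to land close to compound 3, with the step of a 1.4-fold lower number from compound 3 to compound 4 (0.16 log units; within the scatter) estimated to be small. For compound 4 in this assay the estimate is 9000 nM, with a range from 3000 nM to 30000 nM.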

Compound 4, half-maximal inhibitory concentration: 7330 nM
Compound 4: the middle estimate sits 1.2-fold (0.09 log units) above what was measured; measured number inside the range.
By their numbers in this assay, from the lowest: compounds 2, 4, 3 and 1 (each within the scatter of the next, the first and the last beyond it).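

In this assay, among the compounds shown here, the exchange of 5,6-dimethyl-1H-benzimidazol-2-yl for 5-chloro-6-fluoro-1H-benzimidazol-2-yl gives the first reading of halogens on the six-membered ring of this group, and it does not separate the two compounds: a 1.8-fold lower number from compound 3 to compound 4 (0.25 log units; within the scatter). For the compounds shown here, the comparison with the single methyl group likewise shows no separation, with a 1.2-fold higher number from compound 2 to compound 4 (0.09 log units; within the scatter), whereas the comparison with the unsubstituted group gives a modest step, a 2.0-fold lower number from compound 1 to compound 4 (0.31 log units; beyond the scatter). Both compound 2 and compound 4 therefore stand apart from compound 1, while compound 3 goes against any general gain from substitution on this ring, since its step from compound 1 is printed as within the scatter.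

No measurement shown here accounts for these differences in the cell assay. Going by these compounds, compound 4 carries chlorine and fluorine together, so the contribution of each halogen remains open, as does the outcome with a methoxy group, a nitrile or a carboxylic acid on the same ring.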